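Shared-core series: expected cytotoxicity of compound 4

The source may report more compounds than this note shows. Statements on the series, on what has been measured and on what is new or still open speak of the compounds shown alone.

Compound 2 `CCCOC(=O)c1ccc(OCCCCCn2ccc(=O)[nH]c2=O)cc1` has been examined in an ADME assay on HEL cells (Homo sapiens) for cytotoxicity; on this read-out higher numbers stand for lower toxicity in this test and lower numbers for higher toxicity in this test. In this assay compound 2 gives > 100000 nM, which is a limit of the assay rather than a number. Compound 3 `Cc1cc(C)cc(OCCCCCn2ccc(=O)[nH]c2=O)c1` gives > 100000 nM in this assay, again only a limit. Compound 1 `O=c1ccn(CCCCOc2ccc(Br)cc2)c(=O)[nH]1` has "not determined" (no result reported) in this assay. Compound 2 thus sits at the limit of > 100000 nM in this assay, at which 2 of the 3 values shown sit, and no numeric ranking among the values shown is possible. Compound 4 `CC(C)c1ccc(OCCCCCn2ccc(=O)[nH]c2=O)cc1` is still to be measured in this assay. It differs from compound 2 by isopropyl in place of propoxycarbonyl on an aromatic carbon. For the measured compounds named here, no step between measured compounds is available, so the expectation rests on the two limits alone. The step is expected to be none beyond the scatter: a number no higher from compound 2 to compound 4 (the limit leaves the size open). Compound 4 is expected to give 100000 nM in this assay, between 50000 nM and 300000 nM, most likely reported once more as a limit.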

Compound 4, half-maximal cytotoxic concentration: > 100000 nM
Compound 4: a limit, no number; the forecaster's own chance of this, stated with the estimate: 80%; the middle value lies on the limit itself.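

No step can be read from compound 2 to compound 4: both give only a limit in this assay, not a number. The compounds shown leave open whether isopropyl and propoxycarbonyl differ at all on this read-out.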